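This account rests on a few compounds, and the source may have more. Where it says the series, first, only, none or still open, it means among the compounds named here.

The series shares one core, shown in compound 1 `COc1cc(/C=C/C(=O)c2cccc(-n3cc(-c4ccc(Cl)cc4)[nH]c3=O)c2)cc(OC)c1OC`, and is read in a functional assay on HCT-116 cells (Homo sapiens) for inhibition; on this read-out higher numbers stand for weaker inhibition of growth and lower numbers for stronger inhibition of growth. Compound 1 gives 1390 nM. Compound 2 `COc1cc(/C=C/C(=O)c2cccc(-n3cc(-c4ccccc4)[nH]c3=O)c2)ccc1O` gives 1400 nM in this assay, and compound 3 `O=C(/C=C/c1cccc(O)c1)c1cccc(-n2cc(-c3ccc(Cl)cc3)[nH]c2=O)c1` gives 1230 nM. On these three numbers compound 1 stands at the second highest, yet its gaps to compound 2 and to compound 3 both lie within the scatter of the measurement, so the three cannot be told apart on this read-out.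

Compound 4 `COc1cc(/C=C/C(=O)c2cccc(-n3cc(-c4ccccc4)[nH]c3=O)c2)cc(OC)c1OC` has not yet been measured. It differs from compound 1 in one place: hydrogen in place of chloro on an aromatic carbon. Going by the values given here, no measured pair isolates this change. Still, the phenyl found in compound 4 is already carried by compound 2, which gives 1400 nM, indistinguishable from compound 1, which suggests the chloro is not needed for this level of growth inhibition. A step in this assay of no more than the scatter is therefore expected, in either direction.

For compound 4 a value of 1500 nM is expected, within a range from 700 nM to 3500 nM. That estimate corresponds to an expected step of a 1.1-fold higher number from compound 1 to compound 4 (0.03 log units; within the scatter).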

Compound 4, concentration for 50% growth inhibition: 330 nM
Estimate against measurement, compound 4: 4.5-fold (0.66 log units) above; the whole stated range lies above it.
By their numbers in this assay, from the lowest: compound 4; then compounds 3, 1 and 2 (each within the scatter of the next).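

Going by these compounds alone, the step of a 4.2-fold lower number from compound 1 to compound 4 (0.62 log units; beyond the scatter) in this assay is the first comparison that isolates a single change, and it shows that this position is not indifferent to what it carries. In this pair, the change from 4-chlorophenyl to phenyl strengthens inhibition of growth beyond the scatter, so the chloro, para to a large group, is not neutral here, a point the three earlier compounds could not settle because none of them differs from another in one place only. No measurement at hand bears on what lies behind this step.

As far as these compounds go, whether the same change has the same effect with the other substitution patterns seen in compound 2 and compound 3 remains open. So does the outcome with a fluoro, a methyl or an amine at this position.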